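Hydrogen in Place of Bromo on a Weak Inhibitor

The compounds below may be only part of what the source reports. "The series", "measured", "known", "first", "only" and "open" are said of these compounds alone.

Compound 2, `C=CCn1nc(Br)c2c(Br)nc(CCC)n2c1=O`, stands at the edge of what a functional assay for inhibition, with Homo sapiens as the target (on this read-out higher numbers stand for weaker inhibition and lower numbers for stronger inhibition), can resolve. In this assay compound 2 gives only a limit of > 48000 nM, a limit at which, as the limit of > 48000 nM in this assay, at which 1 of the 2 values shown sits, records, one of the two measured values sits. Compound 1, `C=CCn1ncc2c(C)nc(CCC)n2c1=O`, lacks the bromo groups of compound 2. In this assay compound 1 gives 40000 nM. Compound 3, `C=CCn1ncc2c(Br)nc(CCC)n2c1=O`, is yet to be measured; it differs from compound 2 by hydrogen in place of bromo on an aromatic carbon. For the measured compounds named here, no step between measured compounds is known, and the expectation rests on compound 1 and compound 2 alone. The step from compound 2 to compound 3 is expected to be an at least 1.0-fold lower number from compound 2 to compound 3 (0.02 log units; that floor lies within the scatter), not beyond the scatter in either direction. The estimate for compound 3 in this assay is 45000 nM, between 20000 nM and 100000 nM.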

Compound 3, half-maximal inhibitory concentration: > 48000 nM
Compound 3: only a limit was reported; the forecaster's own chance of this, stated with the estimate: 50%; middle value at least 1.0-fold (0.02 log units) away from the limit.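

In this assay compound 3 gives > 48000 nM, which is a limit, so taking away the bromo group on the aromatic carbon next to the ring nitrogen does not bring the compound to a readable value. The step between compound 2 and compound 3 cannot be read, because both compounds rest at a limit: the limit of > 48000 nM in this assay, at which 2 of the 3 values shown sit.

The comparison at the other aromatic carbon, bromo in place of methyl, gives an at least 1.2-fold higher number from compound 1 to compound 3 (0.07 log units; that floor lies within the scatter), so it shows no change beyond the scatter, though the true size of the step may be larger than this floor.

The compounds shown leave open whether this bromo group has any effect on inhibition. They also leave open what an amine or a methoxy group on either aromatic carbon would give in this assay.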